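This account rests on a few compounds, and the source may have more. Where it says the series, first, only, none or still open, it means among the compounds named here.

Measured compounds:
compound 1 `COC(=O)c1c(Nc2ccccc2)sc(C(=O)c2ccc(OC)cc2)c1C` — 36.9%
compound 2 `COc1ccc(C(=O)c2sc(Nc3ccccc3)c(C(=O)O)c2C)cc1` — 52.6%

In a functional assay, with a stated time of 150 min, tested at 25 ug/mL (on this read-out lower numbers stand for a weaker effect and higher numbers for a stronger effect at the one concentration tested), compound 1 gives 36.9%, and compound 2 gives 52.6%. Among the measured compounds shown here, the one step between them, a number 15.7 percentage points higher from compound 1 to compound 2 (beyond the scatter), comes with hydrogen in place of methyl on an oxygen next to a carbonyl group. Compound 2 thus stands highest of the two numbers, with compound 1 the nearest and lower.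

Compound 3 `COc1ccc(Nc2sc(C(=O)c3ccc(OC)cc3)c(C)c2C(=O)O)cc1` differs from compound 2 by methoxy in place of hydrogen on an aromatic carbon: the anilino group becomes a (4-methoxyphenyl)amino group, the methoxy sitting on an aromatic carbon of a six-membered aromatic ring of carbon only, para to a large group. For the measured compounds named here, no measured step touches this ring, so nothing among the measured compounds speaks for or against a change here. The expected step is a number 0.6 percentage points lower from compound 2 to compound 3 (within the scatter), within the scatter. Compound 3 is therefore estimated at 52%, with a range from 30% to 72%.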

Compound 3, a percentage reported as activity, at one concentration (the size of the read-out at that concentration, not a potency): 38.5%
Beside the measured number, compound 3's estimate is 13.5 percentage points above it; the range from low to high includes it.
By their numbers in this assay, from the lowest: compounds 1 and 3 (each within the scatter of the next); then compound 2.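

In this assay, the ring of the anilino group now has its first measured change, and the read-out responds to it: methoxy in place of hydrogen on this aromatic carbon, para to a large group, gives a number 14.1 percentage points lower from compound 2 to compound 3 (beyond the scatter). Among the compounds shown here, the only earlier step lay elsewhere in the molecule, so this shows that the read-out also depends on this ring position and that going from phenyl to 4-methoxyphenyl costs effect on the core of compound 2. No measured evidence here bears on why the number falls.

On these data alone, it remains open whether this fall belongs to methoxy alone or would also follow a chlorine, a hydroxyl or an amine at the same place. As far as these compounds go, it also remains open whether the same change would go the same way with the methyl ester of compound 1 in place of the carboxylic acid.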